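The source may hold more compounds than are shown below. What is called first, only, known or untested is meant among the compounds shown, and "the series" means these compounds.

Of the compounds shown here, three built on the same core have been tested in a functional assay on HeLa cells (Homo sapiens) for cytotoxicity, read by MTT assay; a lower number here means a stronger inhibitor, a higher number a weaker inhibitor. Compound 1 `CCCCC(O)CC(=O)O[C@H](CC=C(C)C)C1=CC(=O)c2c(O)ccc(O)c2C1=O` gives 72200 nM, compound 2 `CCC(CO[C@H](CC=C(C)C)C1=CC(=O)c2c(O)ccc(O)c2C1=O)OC(C)=O` gives 44000 nM, and compound 3 `CC(C)=CC[C@@H](OC(=O)CC(C)(O)C(C)C)C1=CC(=O)c2c(O)ccc(O)c2C1=O` gives 27700 nM. Among these three numbers compound 3 has the lowest; its nearest neighbour is compound 2, within the scatter, and its furthest is compound 1, with a 2.6-fold lower number from compound 1 to compound 3 (0.42 log units; beyond the scatter).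

Compound 4 `CC(C)=CC[C@@H](OCC(C)O)C1=CC(=O)c2c(O)ccc(O)c2C1=O` is not yet measured. It differs from compound 3 at the oxygen on a saturated carbon whose other neighbour is a saturated chain carbon: 2-hydroxypropyl in place of (2-hydroxy-2,3-dimethylbutyl)carbonyl on an oxygen on a saturated carbon.

Among the measured compounds shown here, two measured steps bear on this kind of exchange at that oxygen. From compound 1 to compound 2 a carbonyl-bearing group gave way to a plain chain, with a 1.6-fold lower number from compound 1 to compound 2 (0.22 log units; within the scatter). From compound 2 to compound 3 the reverse kind of swap gave a 1.6-fold lower number from compound 2 to compound 3 (0.20 log units; within the scatter). Both stayed within the scatter, so swapping what hangs on this oxygen has so far moved the read-out little.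

Compound 4 is therefore expected to show no step beyond the scatter, with a 1.4-fold higher number from compound 3 to compound 4 (0.14 log units; within the scatter) as the estimated change. The estimated value for compound 4 in this assay is 38000 nM, expected to fall between 13000 nM and 110000 nM.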

Compound 4, half-maximal inhibitory concentration: 24700 nM
For compound 4 the middle estimate is 1.5-fold (0.19 log units) above the measured one, and the stated range covers the measured number.
By their numbers in this assay, from the lowest: compounds 4, 3, 2 and 1 (each within the scatter of the next, the first and the last beyond it).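

In this assay, the larger group on this oxygen gives way to a much smaller one, with 9 heavy atoms leaving and 4 entering and the carbonyl lost, yet the step stays within the scatter: a 1.1-fold lower number from compound 3 to compound 4 (0.05 log units; within the scatter). Among the compounds shown here, the earlier steps at this oxygen had only exchanged groups of more similar size, so this result extends the near-flat picture to a short 2-hydroxypropyl group with no carbonyl, although a 1.8-fold lower number from compound 2 to compound 4 (0.25 log units; within the scatter) is also within the scatter, while a 2.9-fold lower number from compound 1 to compound 4 (0.47 log units; beyond the scatter) is the one step of these three beyond it, and only modestly so. Nothing available here gives a reason for these small differences.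

The compounds shown leave open whether the hydroxyl of the 2-hydroxypropyl group matters at all, which a plain propyl group at this oxygen would test. They also leave open how the read-out would respond to an amine or a carboxylic acid at the end of this chain, since every group shown so far is built only from carbon and oxygen and carries no net charge.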